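The compounds below may be only part of what the source reports. "The series", "measured", "known", "first", "only" and "open" are said of these compounds alone.

Measured compounds in a functional assay on MCF7 cells (Homo sapiens) for cytotoxicity, read by MTT assay, with a stated time of 48 h; on this read-out higher numbers stand for weaker inhibition and lower numbers for stronger inhibition:
Compound 1, `COc1cc(-c2nnc3n2NC(c2cccs2)C(C(=O)c2ccc(C)cc2)S3)cc(OC)c1OC`, gives 28400 nM.
Compound 2, `COc1ccc(C(=O)C2Sc3nnc(-c4cc(OC)c(OC)c(OC)c4)n3NC2c2ccco2)cc1`, gives a limit of the assay, > 100000 nM, and no number.
Compound 3, `COc1cc(-c2nnc3n2NC(c2ccco2)C(C(=O)c2cccc(Br)c2)S3)cc(OC)c1OC`, gives 91800 nM.

Among these, compound 3 holds the highest of the two numbers reported; its nearest neighbour is compound 1, whose number is lower by a gap that goes beyond the scatter, while compound 2 contributes only a limit.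

The step under consideration leads from compound 3 to compound 4, `COc1cc(-c2nnc3n2NC(c2ccco2)C(C(=O)c2ccc(C)cc2)S3)cc(OC)c1OC`, which has not yet been measured. The change is 4-methylphenyl in place of 3-bromophenyl on a carbonyl carbon.

For the measured compounds named here, only one measured step touches the same carbonyl carbon: an at least 1.0-fold lower number from compound 2 to compound 3 (0.03 log units; that floor lies within the scatter). Going by the values given here, that step starts from a limit, so it shows only that compound 3 is no weaker than compound 2 and gives no size. Among the compounds with values here, compound 1 carries the 4-methylphenyl group that enters here, but it also differs from compound 3 at the saturated ring carbon, so the two values show only that compound 1 sits well below compound 3.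

On this thin basis a modest lowering from compound 3 to compound 4 is expected, a 1.8-fold lower number from compound 3 to compound 4 (0.26 log units; within the scatter), with wide uncertainty. The estimate for compound 4 in this assay is 50000 nM, within a range from 20000 nM to 150000 nM.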

Compound 4, half-maximal inhibitory concentration: > 100000 nM
Compound 4: no number, only a limit (the forecaster's own chance of this, stated with the estimate: 25%); at least 2.0-fold (0.30 log units) between middle value and limit.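

In this assay, for the compounds shown here, 4-methylphenyl in place of 3-bromophenyl on a carbonyl carbon gives an at least 1.0-fold higher number from compound 3 to compound 4 (0.03 log units; that floor lies within the scatter); this floor sets no size for the step, and with furan-2-yl on the saturated ring carbon, the entering group brings no measurable gain. The clearer result concerns the other place: with 4-methylphenyl held on the carbonyl carbon, furan-2-yl in place of thiophen-2-yl on a saturated ring carbon gives an at least 3.5-fold higher number from compound 1 to compound 4 (0.54 log units; beyond the scatter), so the 4-methylphenyl group alone does not account for the lower number of compound 1. The step from compound 2 to compound 4 cannot be read, as both values are limits of the assay: the limit of > 100000 nM in this assay, at which 2 of the 4 values shown sit.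

It remains open how the groups on the carbonyl carbon would rank with thiophen-2-yl on the saturated ring carbon, where compound 1 is the only compound shown. Also open, from the compounds shown here alone, is whether an amine or a carboxylic acid on the phenyl ring in place of the methyl of compound 4 would bring the value back within the range of the assay.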